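The source may report more compounds than this note shows. Statements on the series, on what has been measured and on what is new or still open speak of the compounds shown alone.

Measured so far, in a functional assay on T47D cells (Homo sapiens) for cytotoxicity, read by sulforhodamine B assay, with a stated time of 48 h; on this read-out lower numbers stand for stronger inhibition of growth and higher numbers for weaker inhibition of growth:

Compound 1 `ClCc1ccccc1Cn1cnc2c(Cl)nc(Cl)nc21` gives 5490 nM.
Compound 2 `ClCc1ccccc1Cn1cnc2c(Cl)ncnc21` gives 61700 nM.
Compound 3 `ClCc1cccc(Cn2cnc3c(Cl)ncnc32)c1` gives 12300 nM.

Among these three numbers compound 3 sits second highest: its value is above that of compound 1 and below that of compound 2, and both gaps lie beyond the usual scatter. Within the data shown here, the one change that has been measured directly is the step of an 11-fold higher number from compound 1 to compound 2 (1.05 log units; beyond the scatter), a large shift toward weaker growth inhibition when the chloro group is removed from the shared core.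

Compound 4 `ClCc1cccc(Cn2cnc3c(Cl)nc(Cl)nc32)c1` differs from compound 3 by the opposite change, (chloro in place of hydrogen on an aromatic carbon). The chloro group enters on an aromatic carbon of a six-membered aromatic ring with two nitrogen atoms, part of a fused system of two rings, between two ring nitrogen atoms, meta to another chloro group. Since removing this same group from compound 1 to give compound 2 raised the number sharply, adding it to compound 3 is expected to lower the number by a comparable amount, giving an expected step of an 11-fold lower number from compound 3 to compound 4 (1.05 log units; beyond the scatter) in this assay. Compound 4 is therefore estimated at about 1100 nM, most likely between 450 nM and 2800 nM.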

Compound 4, concentration for total growth inhibition: 4460 nM
Estimate against measurement, compound 4: 4.1-fold (0.61 log units) below; measured number above the stated range.
By their numbers in this assay, from the lowest: compounds 4 and 1 (each within the scatter of the next); then compound 3; then compound 2.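

In this assay the added chloro group on this aromatic carbon, between two ring nitrogen atoms, again goes with a lower number (a 2.8-fold lower number from compound 3 to compound 4 (0.44 log units; beyond the scatter)), so the direction seen with compound 1 and compound 2 also holds on a second core. The size of the step, however, does not carry over from one core to the other: the same change on two cores in this assay, an 11-fold higher number (1.05 log units; beyond the scatter) from compound 1 to compound 2 and a 2.8-fold higher number (0.44 log units; beyond the scatter) from compound 4 to compound 3, 4.1-fold (0.61 log units) apart, beyond the scatter of two such steps. With this chloro group present, compound 4 (4460 nM) and compound 1 (5490 nM) lie within the scatter of each other, while without it compound 3 and compound 2 stand apart.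

The compounds shown carry only hydrogen or chloro at this position, so what an amine or a methoxy group would do there stays open. They also cannot tell why the step differs in size between the two cores.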